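The compounds below may be only part of what the source reports. "The series", "measured", "known", "first", "only" and "open" are said of these compounds alone.

In a functional assay on OVCAR-3 cells (Homo sapiens) for inhibition, read by MTT assay, with a stated time of 24 h (on this read-out lower numbers stand for stronger inhibition and higher numbers for weaker inhibition), compound 1 `CC1(C)[C@H]2CC[C@]1(C)N(Cc1cn(-c3cccc(C#N)c3)nn1)C(=O)C2` gives 230 nM, and compound 2 `CC1(C)[C@H]2CC[C@]1(C)N(Cc1cn(-c3ccc(Br)cc3)nn1)C(=O)C2` gives 140 nM. Going by the values given here, compound 2 therefore stands within the scatter of compound 1, the only other compound measured so far. Compound 3 `CC1(C)[C@H]2CC[C@]1(C)N(Cc1cn(-c3cccc(O)c3)nn1)C(=O)C2` keeps the shared core and carries 3-hydroxyphenyl in place of 4-bromophenyl on an aromatic nitrogen. Among the compounds with values here, one measured step bears on this change, at the same place: a 1.6-fold lower number from compound 1 to compound 2 (0.22 log units; within the scatter), which lies within the scatter. Within the data shown here, it offers no sign of a large effect from the group on this nitrogen, but it rests on only two compounds, and no measured compound carries a 3-hydroxyphenyl group. No shift beyond the scatter is therefore expected in this assay. The expected change is a 1.4-fold higher number from compound 2 to compound 3 (0.15 log units; within the scatter), which stays within the scatter. For compound 3 the estimated value is 200 nM, with an expected range of 80 nM to 500 nM.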

Compound 3, half-maximal inhibitory concentration: 370 nM
Beside the measured number, compound 3's estimate is 1.9-fold (0.27 log units) below it; the measured number falls inside the stated range.
By their numbers in this assay, from the lowest: compounds 2, 1 and 3 (each within the scatter of the next, the first and the last beyond it).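

In this assay, going by these compounds alone, the group on the aromatic nitrogen now yields the first step beyond the scatter: a 2.6-fold higher number from compound 2 to compound 3 (0.42 log units; beyond the scatter), a modest shift showing that this position is not wholly indifferent to the aryl group it carries. The second step, with hydroxy in place of cyano on an aromatic carbon, stays within the scatter at a 1.6-fold higher number from compound 1 to compound 3 (0.21 log units; within the scatter), so this change does not separate compound 1 from compound 3. No supporting data bear on the reason for either step.

The step from compound 2 to compound 3 changes both the substituent and its place on the phenyl ring, so a 4-hydroxyphenyl or 3-bromophenyl group would be needed to tell these apart. Going by these compounds, how an amine or a carboxylic acid on that ring would read also remains open.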